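Aryl exchange on the enol side chain

A few compounds are considered here, and "the series" means these few. Any claim that something is new, unique, unknown or untested is made for them only; others in the source may bear on it.

Measured so far:
compound 1, `COC1=C(C)C(=O)/C(=C(O)/C=C/c2ccc(Br)cc2)C(=O)C1(C)C`: < 4 ug/mL
compound 2, `COC1=C(C)C(=O)/C(=C(O)/C=C/c2cccc(OC)c2)C(=O)C1(C)C`: < 4 ug/mL

In a functional assay on HUVEC cells (Homo sapiens) (a higher number here means that more compound is needed for the effect, a lower number that less compound is needed), compound 1 gives < 4 ug/mL, which is a limit of the assay and not a number. Compound 2 likewise gives < 4 ug/mL in this assay, again only a limit. Among the measured compounds shown here, the single step between measured compounds is therefore a step that the two limits leave unreadable from compound 1 to compound 2, and nothing can be said of its size or direction. For the measured compounds named here, compound 2 thus stands at a limit, with the one further value shown also a limit; the whole series so far rests on (the limit of < 4 ug/mL in this assay, at which 2 of the 2 values shown sit).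

The next compound is compound 3, `COC1=C(C)C(=O)/C(=C(O)/C=C/c2ccccc2C)C(=O)C1(C)C`. It differs from compound 2 as follows: 2-methylphenyl in place of 3-methoxyphenyl on a double-bonded chain carbon bound to a double-bonded chain carbon. Going by the values given here, no readable step bears on this change, since the only measured step is hidden by the two limits, so no size of step in this assay can be derived from the data.

Compound 3 is expected to sit at or beyond the same limit, estimated at 2 ug/mL with a range of 0.5 ug/mL to 6 ug/mL. The expected step is a step that the limit leaves unreadable from compound 2 to compound 3.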

Compound 3, concentration for half-maximal effect: < 4 ug/mL
Compound 3 was reported as a limit; the forecaster's own chance of this, stated with the estimate: 70%; the middle value does not contradict the limit.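

In this assay compound 3 gives < 4 ug/mL as a limit and not a number. The steps from compound 2 to compound 3 and from compound 1 to compound 3 cannot be read, because all the values rest on one limit: the limit of < 4 ug/mL in this assay, at which 3 of the 3 values shown sit. In this assay the compounds shown leave open whether 4-bromophenyl, 3-methoxyphenyl and 2-methylphenyl differ at all.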